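Swapping chloro for nitro on a benzothiazole amide

The compounds below may be only part of what the source reports. "The series", "measured", "known", "first", "only" and "open" are said of these compounds alone.

Measured so far:
compound 1, `CNC(=O)CSc1nc2ccc(NC(=O)c3ccc([N+](=O)[O-])cc3)cc2s1`: > 100000 nM
compound 2, `O=C(CSc1nc2ccc(NC(=O)c3ccc(Cl)cc3)cc2s1)NCc1ccc(Cl)cc1`: 17800 nM

In a functional assay on HepG2 cells (Homo sapiens) for cytotoxicity, read by MTT assay, with a stated time of 48 h (a lower number here means a stronger inhibitor, a higher number a weaker inhibitor), compound 1 gives only a limit, > 100000 nM, not a number. Compound 2 gives 17800 nM in this assay, the only actual number shown here, so there is no measured step to compare it with. Compound 3, `O=C(CSc1nc2ccc(NC(=O)c3ccc([N+](=O)[O-])cc3)cc2s1)NCc1ccc(Cl)cc1`, has not yet been tested in this assay. It differs from compound 2 in one place: nitro in place of chloro on an aromatic carbon. The other nitro-bearing compound, compound 1, sits at the limit of > 100000 nM in this assay, at which 1 of the 2 values shown sits, though it also carries a different amide, so no cause can be drawn from that. Compound 3 is expected to be a weaker inhibitor than compound 2, with a step of a 2.2-fold higher number from compound 2 to compound 3 (0.35 log units; beyond the scatter) in this assay. The estimate for compound 3 is 40000 nM, expected to fall between 12000 nM and 150000 nM, with a real chance that only a limit is reported.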

Compound 3, half-maximal inhibitory concentration: > 100000 nM
Compound 3: only a limit was reported; the forecaster's own chance of this, stated with the estimate: 35%; middle value at least 2.5-fold (0.39 log units) from the limit.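

Within the data shown here, compound 2 and compound 3 differ in one place only, so this pair gives the first clean reading of the change from (4-chlorophenyl)carbonyl to (4-nitrophenyl)carbonyl. In this assay, the change gives an at least 5.6-fold higher number from compound 2 to compound 3 (0.74 log units; beyond the scatter), so at this position, with the rest of the molecule held fixed, chloro gives the stronger result of the two. The true size of that step stays unknown, and the step linking compound 1 and compound 3 cannot be read, because each of those compounds gives only a limit: the limit of > 100000 nM in this assay, at which 2 of the 3 values shown sit.

The compounds shown do not say whether this loss is specific to nitro, since only two groups appear at this position. An amine or a methoxy group in the same place would show how far the reading depends on the group chosen.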